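Removing One Chlorine from a Trichlorophenyl Ether

The source may hold more compounds than are shown below. What is called first, only, known or untested is meant among the compounds shown, and "the series" means these compounds.

Compound 1 `NC1=NC2(CCOCC2)N(OCCCOc2cc(Cl)c(Cl)cc2Cl)C(N)=N1` gives 2360 nM in a functional assay on HL-60 cells (Homo sapiens) for antiproliferative activity, read by MTT assay, with a stated time of 72 h (a higher number here means a weaker inhibitor, a lower number a stronger inhibitor), the highest of the two numbers recorded; compound 2 `NC1=NC2(CCSCC2)N(OCCCOc2ccc(Cl)cc2)C(N)=N1` gives 430 nM in this assay, a lower number, and the gap between compound 1 and compound 2 lies beyond the scatter. Compound 3 `NC1=NC2(CCOCC2)N(OCCCOc2ccc(Cl)cc2Cl)C(N)=N1` has not been measured. It differs from compound 1 in one place: hydrogen in place of chloro on an aromatic carbon. Going by the values given here, no step between measured compounds that differ only in one place is known, so the expected size rests on the change alone, and a modest step toward a lower number is expected a 1.6-fold lower number from compound 1 to compound 3 (0.20 log units; within the scatter). Compound 3 is estimated at 1500 nM, within 500 nM to 4500 nM.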

Compound 3, half-maximal inhibitory concentration: 330 nM
Beside the measured number, compound 3's estimate is 4.5-fold (0.66 log units) above it; measured number outside the range, below it.
By their numbers in this assay, from the lowest: compounds 3 and 2 (each within the scatter of the next); then compound 1.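

In this assay, going by these compounds alone, the change from 2,4,5-trichlorophenyl to 2,4-dichlorophenyl gives a 7.2-fold lower number from compound 1 to compound 3 (0.85 log units; beyond the scatter) and is the first step that isolates a single place. It shows that this one chloro on the aromatic ring, with the rest of compound 1 unchanged, matters beyond the scatter. Nothing available here accounts for the size of this step. On these data alone, what a fluoro, a methoxy or an amine would do at this position stays open, as does the effect of removing either remaining chloro.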